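A few compounds are considered here, and "the series" means these few. Any claim that something is new, unique, unknown or untested is made for them only; others in the source may bear on it.

In an ADME assay on MT4 cells (Homo sapiens) for cytotoxicity (on this read-out higher numbers stand for lower toxicity in this test and lower numbers for higher toxicity in this test), compound 1 (`COC(=O)N[C@H](C(=O)NN(CCC[C@@](O)(Cc1ccccc1)C(=O)N[C@H]1c2ccccc2C[C@H]1O)Cc1ccc(Cl)cc1)C(C)(C)C`) gives > 10000 nM, which is a limit of the assay and not a number. Compound 2 (`COC(=O)N[C@H](C(=O)NN(CCC[C@@](O)(Cc1ccccc1)C(=O)N[C@H]1c2ccccc2C[C@H]1O)Cc1ccc(-c2ccccn2)cc1)C(C)(C)C`) gives > 10000 nM, which is also only a limit. Within the data shown here, compound 2 therefore has no exact position on this scale, and the same holds for the whole series so far: the limit of > 10000 nM in this assay, at which 2 of the 2 values shown sit. Compound 3 (`COC(=O)N[C@H](C(=O)NN(CCC[C@@](O)(Cc1ccccc1)C(=O)N[C@H]1c2ccccc2C[C@H]1O)Cc1ccc(-c2csc(C)n2)cc1)C(C)(C)C`) carries 2-methyl-1,3-thiazol-4-yl in place of pyridin-2-yl on an aromatic carbon. Among the measured compounds shown here, the one measured change at this place is a step that the two limits leave unreadable from compound 1 to compound 2, with pyridin-2-yl replacing chloro. That step gives no size to carry forward, but it shows no drop to a measurable number. No shift beyond the usual scatter is therefore expected, and the estimated change is a step that the limit leaves unreadable from compound 2 to compound 3. For compound 3 the expected value is 15000 nM, with an estimated range from 7000 nM to 40000 nM, and the assay will probably report only a limit.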

Compound 3, half-maximal cytotoxic concentration: > 10000 nM
Compound 3 ended at the assay's limit; the forecaster's own chance of this, stated with the estimate: 85%; the middle value does not contradict the limit.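

No new step can be read for compound 1, compound 2 or compound 3, because all three stop at the same limit, which is not a number: the limit of > 10000 nM in this assay, at which 3 of the 3 values shown sit. The compounds shown leave open whether chloro, pyridin-2-yl and 2-methyl-1,3-thiazol-4-yl differ at all in this assay.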